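The source may report more compounds than this note shows. Statements on the series, on what has been measured and on what is new or still open speak of the compounds shown alone.

Compound 1 `Cc1nc(-c2cccnc2)sc1-c1nnc(-c2cccc(Cl)c2Cl)o1`: > 100 ug/mL
Compound 2 `Cc1nc(-c2cccnc2)sc1-c1nnc(-c2ccccc2[N+](=O)[O-])o1`: > 100 ug/mL

Going by the values given here, both compounds have been measured in an ADME assay on THP-1 cells (Homo sapiens) for cytotoxicity, read by MTT assay; on this read-out higher numbers stand for lower toxicity in this test and lower numbers for higher toxicity in this test. Compound 1 gives > 100 ug/mL, which is a limit of the assay and not a number. Compound 2 gives > 100 ug/mL, and this too is only a limit. Compound 1 therefore has no exact position on this scale, and the only other measured result offers no number to set against it. What the data show so far is the limit of > 100 ug/mL in this assay, at which 2 of the 2 values shown sit.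

Compound 3 `Cc1nc(-c2cccnc2)sc1-c1nnc(-c2ccncc2)o1` has not yet been measured. It keeps the core of compound 1 but carries pyridin-4-yl in place of 2,3-dichlorophenyl on an aromatic carbon. Among the compounds with values here, with no measured step to draw on, the expectation rests only on the shared limit of compound 1 and compound 2, so no shift in either direction beyond the usual scatter is expected in this assay. The estimated step is a step that the limit leaves unreadable from compound 1 to compound 3. A report of compound 3 as a limit again would be no surprise. For compound 3 the estimated value is 120 ug/mL, with an expected range from 50 ug/mL to 250 ug/mL.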

Compound 3, half-maximal cytotoxic concentration: > 100 ug/mL
Compound 3 ended at the assay's limit; the forecaster's own chance of this, stated with the estimate: 70%; the middle value is on the limit's open side.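

Compound 1 and compound 3 both stand only at a limit in this assay, so no step between them can be read, and the evidence stops at this: the limit of > 100 ug/mL in this assay, at which 3 of the 3 values shown sit.

The compounds shown leave open where compound 1, compound 2 and compound 3 lie on this scale, and whether any change on the shared core would yield an exact value.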